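Changing the aryl group on the carbonyl: compound 3 to compound 4

The source may report more compounds than this note shows. Statements on the series, on what has been measured and on what is new or still open speak of the compounds shown alone.

Of the compounds shown here, three built on one shared core have been tested in a functional assay on OVCAR-5 cells (Homo sapiens) for cytotoxicity, read by sulforhodamine B assay, with a stated time of 48 h, tested at 0.01 uM; on this read-out higher numbers stand for a weaker effect at the one concentration tested and lower numbers for a stronger effect. Compound 1 `COc1cc(-c2cc(/C=C/C(=O)c3ccc(N)cc3)[nH]n2)cc(OC)c1OC` gives 90%. Compound 2 `COc1ccc(C(=O)/C=C/c2cc(-c3cc(OC)c(OC)c(OC)c3)n[nH]2)cc1OC` gives 101%, and compound 3 `COc1ccc(C(=O)/C=C/c2cc(-c3cc(OC)c(OC)c(OC)c3)n[nH]2)cc1` gives 99%. Among these three numbers compound 3 stands second highest, but its value lies within the scatter of both compound 2 and compound 1, so no real order among them can be read. All the changes that separate the three compounds sit on the same carbonyl carbon: a number 11 percentage points higher from compound 1 to compound 2 (beyond the scatter), a number 9 percentage points higher from compound 1 to compound 3 (within the scatter) and a number 2 percentage points lower from compound 2 to compound 3 (within the scatter). Only the first of these reaches beyond the scatter, and only modestly; the whole set sits near the point where the cells are hardly affected at this concentration.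

Compound 4 `COc1cc(-c2cc(/C=C/C(=O)c3ccc(F)c(F)c3)[nH]n2)cc(OC)c1OC` has not yet been measured. It differs from compound 3 at that same place: 3,4-difluorophenyl in place of 4-methoxyphenyl on a carbonyl carbon. The steps seen so far at this carbonyl carbon, none larger than a number 11 percentage points higher from compound 1 to compound 2 (beyond the scatter), were all small, so no step beyond the scatter is expected in this assay. Compound 4 is therefore expected to give about 97%, with a likely range from 85% to 108%. This amounts to an expected step of a number 2 percentage points lower from compound 3 to compound 4 (within the scatter).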

Compound 4, a percentage reported as activity, at one concentration (the size of the read-out at that concentration, not a potency): 99%
The estimate for compound 4 lay 2 percentage points below the measured number; the range from low to high includes it.
By their numbers in this assay, from the lowest: compounds 1, 3, 4 and 2 (each within the scatter of the next, the first and the last beyond it).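

The group on the carbonyl carbon can be exchanged here for one with a different make-up: 3,4-difluorophenyl carries fluorine instead of the oxygen of 4-methoxyphenyl and has no hydrogen-bond acceptor, yet in this assay the exchange gives no change at the digits printed from compound 3 to compound 4 (within the scatter). The other two exchanges at this carbon also stay small, with a number 2 percentage points lower from compound 2 to compound 4 (within the scatter) and a number 9 percentage points higher from compound 1 to compound 4 (within the scatter), so this fluorinated ring cannot be told apart from any of the three earlier aryl groups in this measurement, and it adds a group without oxygen or nitrogen to the aryl groups that fit this pattern. No measurement is available that would explain this lack of separation.

Because every compound here was read at one concentration and sits close to the level of hardly affected cells, these numbers cannot show whether the aryl groups would separate under conditions where the effect is stronger. Going by these compounds, it also remains open whether a quite different group on the carbonyl carbon, such as a carboxylic acid, an amine or a longer alkyl chain, would move the number beyond the scatter.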